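Methoxy in Place of a Selenium-Bearing Chain on a Quinoline Core

The compounds below may be only part of what the source reports. "The series", "measured", "known", "first", "only" and "open" are said of these compounds alone.

Compounds measured so far:
compound 1, `OCC#CCSc1cnc2ccccc2c1Cl`: 4.1 ug/mL
compound 2, `OCC#CCSc1cnc2ccccc2c1[Se]CC#CCBr`: 0.2 ug/mL
compound 3, `CSc1c(SCC#CCO)cnc2ccccc12`: 13.9 ug/mL

In a functional assay on CCRF-CEM cells (Homo sapiens) for cytotoxicity, read by sulforhodamine B assay, with a stated time of 72 h (a higher number here means a weaker inhibitor, a lower number a stronger inhibitor), compound 2 gives the lowest of the three numbers. Compound 1 sits higher, as the step of a 21-fold lower number from compound 1 to compound 2 (1.31 log units; beyond the scatter) shows, and compound 3 sits highest of all, as the step of a 70-fold higher number from compound 2 to compound 3 (1.84 log units; beyond the scatter) shows; both steps lie beyond the scatter, so compound 2 stands as the strongest inhibitor of the three.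

Compound 4, `COc1c(SCC#CCO)cnc2ccccc12`, has not yet been measured. Compared with compound 2 it shows (a group of 2 heavy atoms (1 carbon, 1 oxygen; no ring) in place of a group of 6 heavy atoms (4 carbon, 1 selenium, 1 bromine; no ring), on an aromatic carbon). Within the data shown here, two measured steps bear on this. The step of a 70-fold higher number from compound 2 to compound 3 (1.84 log units; beyond the scatter) is the closest analogue, since there too a group of 6 heavy atoms gave way to a group of 2 heavy atoms on the same aromatic carbon, and the number rose greatly. The step of a 3.4-fold higher number from compound 1 to compound 3 (0.53 log units; beyond the scatter) shows that a methylsulfanyl group brings a modestly higher number than a chloro group at that position. Among the measured compounds shown here, a methoxy group has no measured precedent here, so the size of its own effect relative to methylsulfanyl is not known from these data.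

On that basis a large rise is expected, a 60-fold higher number from compound 2 to compound 4 (1.78 log units; beyond the scatter). For compound 4 the estimated value in this assay is 12 ug/mL, with a range from 4 ug/mL to 35 ug/mL.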

Compound 4, concentration for 50% inhibition: 22 ug/mL
Compound 4: the middle estimate sits 1.8-fold (0.26 log units) below what was measured, within the range that was stated.
By their numbers in this assay, from the lowest: compound 2; then compound 1; then compounds 3 and 4 (each within the scatter of the next).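

In this assay, among these compounds, the step of a 1.6-fold higher number from compound 3 to compound 4 (0.20 log units; within the scatter) leaves methoxy and methylsulfanyl indistinguishable on this aromatic carbon opposite the ring nitrogen, the first comparison of two small groups at this place. The step of a 5.4-fold higher number from compound 1 to compound 4 (0.73 log units; beyond the scatter) places methoxy on the same side of chloro as methylsulfanyl, giving a second small group that reads weaker than chloro rather than a single case. The step of a 110-fold higher number from compound 2 to compound 4 (2.04 log units; beyond the scatter) repeats with methoxy the large gap first seen with methylsulfanyl, which shows that the low number of compound 2 does not depend on one particular small replacement, though no measurement offered here explains any of these differences.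

The compounds shown leave open which part of the chain on compound 2 matters, the selenium, the bromine or the triple bond, as that chain leaves whole in every step and none of its parts is varied alone. They also leave open how an amine, a carboxylic acid or a longer chain holding only carbon and oxygen would read on this same aromatic carbon of the shared core.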